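Pentyl in place of 3-methylphenyl: cytotoxicity outlook

The compounds below may be only part of what the source reports. "The series", "measured", "known", "first", "only" and "open" are said of these compounds alone.

Compound 1 `OB1OCc2ccc(-n3cccc3Sc3ccc(Cl)cc3)cc21` and compound 2 `Cc1cccc(C(=O)c2ccn(-c3ccc4c(c3)B(O)OC4)c2)c1` have both been tested in an ADME assay on L929 cells (Mus musculus) for cytotoxicity, read by resazurin assay, with a stated time of 72 h; on this read-out higher numbers stand for weaker inhibition and lower numbers for stronger inhibition. In this assay compound 1 gives > 10 ug/mL, which is a limit of the assay and not a number. Compound 2 likewise gives > 10 ug/mL in this assay, again only a limit. Among the compounds with values here, both values thus sit at the limit of > 10 ug/mL in this assay, at which 2 of the 2 values shown sit, so compound 2 stands exactly where the only other value shown stands, with no number to separate the two.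

Compound 3 `CCCCCC(=O)c1ccn(-c2ccc3c(c2)B(O)OC3)c1` has not yet been measured. It differs from compound 2 by pentyl in place of 3-methylphenyl on a carbonyl carbon. Within the data shown here, no step between measured compounds is available to size such a change. The step from compound 2 to compound 3 in this assay is expected to be a step that the limit leaves unreadable from compound 2 to compound 3, none beyond the scatter. Compound 3 is therefore estimated at 15 ug/mL, between 8 ug/mL and 40 ug/mL, most likely reported again only as a limit.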

Compound 3, half-maximal inhibitory concentration: > 10 ug/mL
Compound 3 was reported as a limit; the forecaster's own chance of this, stated with the estimate: 80%; the middle value is on the limit's open side.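

In this assay compound 3 gives > 10 ug/mL, a limit of the assay and not a number. Within the data shown here, compound 2 also stands at a limit, so no step from compound 2 to compound 3 can be read. As far as these compounds go, how far either compound lies past its limit, and whether pentyl and 3-methylphenyl differ at all on this read-out, stays open.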